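Swapping the aryl group on the piperazine for a pyridine

The source may hold more compounds than are shown below. What is called first, only, known or untested is meant among the compounds shown, and "the series" means these compounds.

Three compounds share one core and differ only in the aromatic group attached to an amine nitrogen in a ring. Compound 1 `Nc1scc(CN2CCN(c3ccc(Cl)cc3Cl)CC2)c1C(=O)c1ccc(Cl)cc1` gives -11% in a functional assay on CHO cells with adenosine receptor A1 (Homo sapiens) as the target, read by cAMP accumulation and immunoassay, with a stated time of 6 min, tested at 0.1 uM; a higher number here means a weaker effect of the compound at the concentration tested, a lower number a stronger effect. Compound 2 `Nc1scc(CN2CCN(c3ccc(Cl)cc3F)CC2)c1C(=O)c1ccc(Cl)cc1` gives -9.4% in this assay, and the step of a number 1.6 percentage points higher from compound 1 to compound 2 (within the scatter) stays within the scatter. Compound 3 `Nc1scc(CN2CCN(c3cccc(C(F)(F)F)c3)CC2)c1C(=O)c1ccc(Cl)cc1` gives -30%, the lowest of the three numbers, lying a number 19 percentage points lower from compound 1 to compound 3 (beyond the scatter) and a number 20.6 percentage points lower from compound 2 to compound 3 (beyond the scatter).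

Compound 4 `Nc1scc(CN2CCN(c3ccncc3)CC2)c1C(=O)c1ccc(Cl)cc1` has not been measured. It differs from compound 3 in one place: pyridin-4-yl in place of 3-(trifluoromethyl)phenyl on an amine nitrogen in a ring. The two steps that bear on this change, from compound 1 to compound 3 and from compound 2 to compound 3, both replaced the group on the same ring nitrogen and both moved the number by a modest amount. Within the data shown here, no measured step introduces a pyridine, so the direction is uncertain; a modest step back toward the numbers of compounds 1 and 2 is expected, that is a number 15 percentage points higher from compound 3 to compound 4 (beyond the scatter). In this assay compound 4 is therefore estimated at -15%, within a range from -40% to 10%.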

Compound 4, a percentage reported as activity, at one concentration (the size of the read-out at that concentration, not a potency): 1.4%
Compound 4: the middle estimate sits 16.4 percentage points below what was measured; the range from low to high includes it.
By their numbers in this assay, from the lowest: compound 3; then compounds 1 and 2 (each within the scatter of the next); then compound 4.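

The group on this ring nitrogen can move the number in either direction from the halogenated phenyl compounds: in this assay, the pyridin-4-yl group gives a number 12.4 percentage points higher from compound 1 to compound 4 (beyond the scatter) and a number 10.8 percentage points higher from compound 2 to compound 4 (beyond the scatter), the opposite direction to the 3-(trifluoromethyl)phenyl group. The widest gap at this position, a number 31.4 percentage points higher from compound 3 to compound 4 (beyond the scatter), comes with the first ring here that holds a nitrogen, and it leaves compound 4 with the highest number of the four. No measurement shown here explains this shift.

Compound 4 both loses the trifluoromethyl group and gains a ring nitrogen, so the compounds shown cannot separate these two changes. A plain phenyl group or a pyridin-3-yl group would help tell them apart.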